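Phenyl for propyl on the ring nitrogen of a pyrazolodiazepinone

The source may report more compounds than this note shows. Statements on the series, on what has been measured and on what is new or still open speak of the compounds shown alone.

Compound 1 `CCCCc1nn(C)c2c1C(c1ccccc1Cl)=NCC(=O)N2`: > 500 mg/kg
Compound 2 `CCCn1nc(C)c2c1NC(=O)CN=C2c1ccccc1Cl`: 63 mg/kg

Of the compounds shown here, two sharing one core have been tested in a functional assay on the whole organism with Rattus norvegicus as the target; a lower number here means that less compound is needed, a higher number that more compound is needed for the effect. Compound 1 did not reach an effect within the tested range, and its value, > 500 mg/kg, is a limit of the assay rather than a number. Among the compounds with values here, compound 2 is the only compound with a measured number: in this assay compound 2 gives 63 mg/kg. Within the data shown here, with only one number and one limit, there is no measured step between compounds from which a trend could be read.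

Compound 3 `Cc1nn(-c2ccccc2)c2c1C(c1ccccc1Cl)=NCC(=O)N2` has not yet been tested. It differs from compound 2 in one place: phenyl in place of propyl on an aromatic nitrogen. Among the measured compounds shown here, no measured pair shows what this exchange does, so any expectation rests on compound 2 alone. From the compounds shown here alone, the estimate for compound 3 places it near compound 2, with a step of a 1.6-fold lower number from compound 2 to compound 3 (0.20 log units; within the scatter) expected, and a wide range because the direction is unknown. Compound 3 is therefore expected to give about 40 mg/kg, between 8 mg/kg and 200 mg/kg.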

Compound 3, minimum effective dose: 500 mg/kg
The estimate for compound 3 lay 13-fold (1.10 log units) below the measured number, outside the stated range (above it).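

In this assay, phenyl in place of propyl on an aromatic nitrogen brings a 7.9-fold higher number from compound 2 to compound 3 (0.90 log units; beyond the scatter). Within the data shown here, this is the first measured step, and it shows that the group on this nitrogen matters: for this one pair, more compound is needed with phenyl than with propyl. A further rise from this exchange might no longer appear as a number, given where the scale ends: the limit of > 500 mg/kg in this assay, at which 1 of the 3 values shown sits.

One pair cannot tell whether the ring itself or the larger count of carbon atoms lies behind the step. An ethyl or a benzyl group on the same nitrogen would help separate the two, and a chain ending in an amine would show how this position responds to a very different kind of group.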